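Compound 3: replacing the cyclobutyl of compound 2

This account rests on a few compounds, and the source may have more. Where it says the series, first, only, none or still open, it means among the compounds named here.

Compound 1 `COC(=O)/C=C/n1ccnc1[N+](=O)[O-]` gives 16 ug/mL
Compound 2 `[O-][n+]1nc(NC2CCC2)[n+]([O-])c2ccccc21` gives 8.9 ug/mL

In an ADME assay on Vero cells (Chlorocebus sabaeus) for cytotoxicity, read by CellTiter-Glo, with a stated time of 72 h (on this read-out lower numbers stand for higher toxicity in this test and higher numbers for lower toxicity in this test), compound 2 gives 8.9 ug/mL and compound 1 gives 16 ug/mL as values within the scatter of each other. Compound 3 `COCC(C)Nc1n[n+]([O-])c2ccccc2[n+]1[O-]` has not yet been measured. The change 1-(methoxymethyl)ethyl in place of cyclobutyl on a nitrogen on an aromatic ring puts 1-(methoxymethyl)ethyl in place of cyclobutyl on a nitrogen on an aromatic ring. Going by the values given here, no measured pair shows this change, so no step beyond the scatter is expected in this assay and the direction stays open. The estimated step of a 1.2-fold higher number from compound 2 to compound 3 (0.09 log units; within the scatter) is therefore small. Compound 3 is estimated at 11 ug/mL with 4 ug/mL to 30 ug/mL as its expected range.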

Compound 3, half-maximal cytotoxic concentration: > 50 ug/mL
Compound 3: only a limit was reported; the forecaster's own chance of this, stated with the estimate: 5%; at least 4.5-fold (0.65 log units) between middle value and limit.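

In this assay, the group on the nitrogen on an aromatic ring matters to the read-out: 1-(methoxymethyl)ethyl in place of cyclobutyl gives an at least 5.6-fold higher number from compound 2 to compound 3 (0.74 log units; beyond the scatter), the only step shown so far. Compound 3 gives > 50 ug/mL, which is a limit of the assay and not a number, so the full size of the step stays unknown: the limit of > 50 ug/mL in this assay, at which 1 of the 3 values shown sits.

The change removes the ring and adds an oxygen at once, and the compounds shown do not tell these two apart. A plain butyl chain, or a cyclobutyl carrying a methoxy group, on the same nitrogen would separate them.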